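Five-membered ring swap on the shared core; microsomal clearance

This account rests on a few compounds, and the source may have more. Where it says the series, first, only, none or still open, it means among the compounds named here.

Measured compounds:
Compound 1 `COc1cc(N2CCN(C(=O)N[C@@H](C)c3cccc4ccccc34)CC2)ccc1-n1cc(C)nn1`: 230 mL.min-1.g-1
Compound 2 `COc1cc(N2CCN(C(=O)N[C@@H](C)c3cccc4ccccc34)CC2)ccc1-n1cnc(C)n1`: 110 mL.min-1.g-1
Compound 3 `COc1cc(N2CCN(C(=O)N[C@@H](C)c3cccc4ccccc34)CC2)ccc1-c1cnc(C)o1`: 130 mL.min-1.g-1

All three share one core and differ only in the five-membered ring on the aromatic carbon ortho to the methoxy group. In an ADME assay on microsomes from liver (Rattus norvegicus) for metabolic stability, read by LC-MS (a higher number here means faster removal of the compound, a lower number slower removal), compound 1 gives 230 mL.min-1.g-1, compound 2 gives 110 mL.min-1.g-1 and compound 3 gives 130 mL.min-1.g-1. Compound 3 sits within the usual scatter of both neighbours: a 1.8-fold lower number from compound 1 to compound 3 (0.25 log units; within the scatter) and a 1.2-fold higher number from compound 2 to compound 3 (0.07 log units; within the scatter). Among the compounds with values here, the only step here that passes the scatter is a 2.1-fold lower number from compound 1 to compound 2 (0.32 log units; beyond the scatter), and even that is modest.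

Compound 4 `COc1cc(N2CCN(C(=O)N[C@@H](C)c3cccc4ccccc34)CC2)ccc1-c1cnn(C)c1` is not yet measured. Its change from compound 3 is 1-methyl-1H-pyrazol-4-yl in place of 2-methyl-1,3-oxazol-5-yl on an aromatic carbon. The three measured steps all exchange one five-membered heteroaromatic ring for another at this same position, and together they span only a narrow band in this assay. On that basis the step of no change at the digits printed from compound 3 to compound 4 (within the scatter) is expected to stay within the scatter, with no clear direction. Compound 4 is therefore estimated at 130 mL.min-1.g-1 in this assay, with a range from 65 mL.min-1.g-1 to 260 mL.min-1.g-1. The band around compound 1 and compound 2 sets the width of that range.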

Compound 4, intrinsic clearance in microsomes: 150 mL.min-1.g-1
Compound 4: middle estimate off by 1.2-fold (0.06 log units), on the low side; low and high end bracket the measured number.
By their numbers in this assay, from the lowest: compounds 2, 3, 4 and 1 (each within the scatter of the next, the first and the last beyond it).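

In this assay, 1-methyl-1H-pyrazol-4-yl in place of 2-methyl-1,3-oxazol-5-yl gives a step within the scatter (a 1.2-fold higher number from compound 3 to compound 4 (0.06 log units; within the scatter)), so exchanging the ring oxygen for a second ring nitrogen, at the same counts of heavy atoms, donors and acceptors, has no readable effect at this position. Compound 4 also lies within the scatter of both compounds that define the series' one larger gap (a 1.4-fold higher number from compound 2 to compound 4 (0.13 log units; within the scatter); a 1.5-fold lower number from compound 1 to compound 4 (0.19 log units; within the scatter)), and that gap (a 2.1-fold lower number from compound 1 to compound 2 (0.32 log units; beyond the scatter)) remains the only exception to a pattern of ring swaps within the scatter among these four compounds. The data hold no independent measurement that could account for where compound 4 falls.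

Every ring here is a methyl-bearing five-membered aromatic ring with two or three hetero atoms, so the series cannot show whether this position would respond to a carboxylic acid or an amine in place of that methyl, or to a nitrile in place of the whole ring. It also leaves open whether the narrow spread would persist if the methoxy group ortho to the ring were exchanged for another group, such as an ethoxy group.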